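The source may hold more compounds than are shown below. What is called first, only, known or untested is meant among the compounds shown, and "the series" means these compounds.

In an ADME assay on SH-SY5Y cells (Homo sapiens) for cytotoxicity, read by MTT assay, with a stated time of 72 h (a higher number here means a weaker inhibitor, a lower number a stronger inhibitor), compound 1 `Cc1ccc(C(=O)N2CCN(CC(=O)N3CCN(CCCc4c[nH]c5ccccc45)CC3)CC2)cc1` reports only a limit, > 200000 nM. Compound 2 `COc1cccc(C(=O)N2CCN(CC(=O)N3CCN(CCCc4c[nH]c5ccccc45)CC3)CC2)c1` also reports only a limit, > 200000 nM. Among the compounds with values here, compound 3 `Cc1ccc(C(=O)N2CCN(CC(=O)N3CCN(CCCc4c[nH]c5ccc(F)cc45)CC3)CC2)cc1` gives 119000 nM, the only true number so far; the other readings rest on (the limit of > 200000 nM in this assay, at which 2 of the 3 values shown sit). Compound 4 `O=C(CN1CCN(C(=O)c2ccccc2Br)CC1)N1CCN(CCCc2c[nH]c3ccc(F)cc23)CC1` carries 2-bromophenyl in place of 4-methylphenyl on a carbonyl carbon. Within the data shown here, the one earlier swap at this carbonyl carbon gives no size, being a step that the two limits leave unreadable from compound 1 to compound 2. Adding fluoro elsewhere gave an at least 1.6-fold lower number from compound 1 to compound 3 (0.22 log units; that floor lies within the scatter), which offers little guidance. With no readable precedent, the expected change is a 1.1-fold lower number from compound 3 to compound 4 (0.03 log units; within the scatter), so no step beyond the scatter is expected. For compound 4 the estimated value is 110000 nM, with an expected range of 50000 nM to 200000 nM.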

Compound 4, half-maximal inhibitory concentration: 79100 nM
Compound 4: the middle estimate sits 1.4-fold (0.14 log units) above what was measured; measured number inside the range.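

In this assay, the carbonyl carbon now gives its first readable step: 2-bromophenyl in place of 4-methylphenyl produces a 1.5-fold lower number from compound 3 to compound 4 (0.18 log units; within the scatter). This exchange of two aromatic rings therefore moves the number no further than repeated measurements would. The earlier step at this carbon cannot be read, since both of its values are limits: the limit of > 200000 nM in this assay, at which 2 of the 4 values shown sit.

As far as these compounds go, whether an amine or a carboxylic acid in place of 2-bromophenyl would produce a step beyond the scatter remains open. So does the effect of 2-bromophenyl on the core without fluoro.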